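The source may report more compounds than this note shows. Statements on the series, on what has been measured and on what is new or still open speak of the compounds shown alone.

Three compounds have been measured in an assay on CHO cells for agonist activity at 5-hydroxytryptamine receptor 1D (Homo sapiens), read by GTPgammaS binding; on this read-out higher numbers stand for an effect only at larger amounts of compound and lower numbers for an effect already at smaller amounts:

Compound 1, `O=S(=O)(NCC1CCN(CCCc2c[nH]c3ccc(-n4cnnc4)cc23)CC1)c1ccccc1`, gives 12 nM.
Compound 2, `COC[C@H](NC1CCN(CCCc2c[nH]c3ccc(-n4cnnc4)cc23)CC1)c1ccccc1`, gives 0.9 nM.
Compound 3, `CC(C)=CCN(C)C1CCN(CCCc2c[nH]c3ccc(-n4cnnc4)cc23)CC1`, gives 1.8 nM.

Compound 3 holds the second highest of the three numbers. Its nearest neighbour is compound 2, with a 2.0-fold higher number from compound 2 to compound 3 (0.30 log units; within the scatter), a gap within the scatter. Its furthest is compound 1, with a 6.7-fold lower number from compound 1 to compound 3 (0.82 log units; beyond the scatter), a change beyond the scatter. The two measured steps away from compound 1 both swap out the ((phenylsulfonyl)amino)methyl group, and both lower the number, whether the entering group is (2-methoxy-1-phenylethyl)amino, with a 13-fold lower number from compound 1 to compound 2 (1.12 log units; beyond the scatter), or methyl(3-methylbut-2-en-1-yl)amino.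

Compound 4, `CN(Cc1ccsc1)C1CCN(CCCc2c[nH]c3ccc(-n4cnnc4)cc23)CC1`, has not yet been measured. It differs from compound 3 in one place: thiophen-3-yl in place of 2-methylprop-1-en-1-yl on a saturated chain carbon bound to an amine nitrogen. Among the measured compounds shown here, no measured step changes this same group, so the closest guide is the step from compound 2 to compound 3, where swapping a group bearing a phenyl ring for an alkenyl chain stayed within the scatter. On that basis no step beyond the scatter is expected in this assay, and the estimate for compound 4 is 1.5 nM, between 0.6 nM and 4 nM, meaning an expected 1.2-fold lower number from compound 3 to compound 4 (0.08 log units; within the scatter).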

Compound 4, half-maximal effective concentration: 4.2 nM
Compound 4: the middle estimate sits 2.8-fold (0.45 log units) below what was measured, and the stated range ends below it.
By their numbers in this assay, from the lowest: compounds 2 and 3 (each within the scatter of the next); then compound 4; then compound 1.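

Among the compounds shown here, no earlier step touched this group, and in this assay the change to thiophen-3-yl from 2-methylprop-1-en-1-yl gives a 2.3-fold higher number from compound 3 to compound 4 (0.37 log units; beyond the scatter) and so lies beyond the scatter, though only modestly. The group on this saturated chain carbon bound to an amine nitrogen therefore affects the number, even with the methyl group on the amine nitrogen and the rest of the molecule unchanged. Compound 4 still improves on the ((phenylsulfonyl)amino)methyl compound, with a 2.9-fold lower number from compound 1 to compound 4 (0.46 log units; beyond the scatter) on that swap, but it loses ground against the (2-methoxy-1-phenylethyl)amino compound, with a 4.7-fold higher number from compound 2 to compound 4 (0.67 log units; beyond the scatter) on that one.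

Going by these compounds, whether the sulfur or the ring itself goes with the higher number stays open, and a furan-3-yl or a cyclopentyl group on the same carbon would help separate the two. Nothing measured here gives a reason for this step.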